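Pyrazolone aryl amides on two cores: cytotoxicity limits

The compounds below may be only part of what the source reports. "The series", "measured", "known", "first", "only" and "open" are said of these compounds alone.

Compound 1 `O=C(Nc1ccc(Oc2ccnc3[nH]ccc23)c(F)c1)c1nn(-c2ccc(Cl)cc2)ccc1=O` and compound 2 `COc1ccc(-n2ccc(=O)c(C(=O)Nc3ccc(Oc4ccnc5[nH]ccc45)c(F)c3)n2)cc1` share one core, while compound 3 `Cn1ccc2c(Oc3ccc(NC(=O)c4nn(-c5ccc(Cl)cc5)ccc4=O)cc3)ccnc21` and compound 4 `COc1ccc(-n2ccc(=O)c(C(=O)Nc3ccc(Oc4ccnc5c4ccn5C)cc3)n2)cc1` share a second; the difference between the two cores is not broken down here. In a functional assay on A549 cells (Homo sapiens) for cytotoxicity, read by MTT assay, with a stated time of 72 h (on this read-out lower numbers stand for stronger inhibition and higher numbers for weaker inhibition), compound 1 reaches only the limit of the assay, > 60000 nM. In this assay compound 2 likewise gives only a limit, > 60000 nM. In this assay compound 3 also sits at a limit, > 60000 nM. The change from compound 1 to compound 2 is methoxy in place of chloro on an aromatic carbon. The step that the two limits leave unreadable from compound 1 to compound 2 has no readable size; both of its ends are limits, as the limit of > 60000 nM in this assay, at which 3 of the 3 values shown sit, shows, with every value in the set standing there.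

The change from compound 3 to compound 4 is methoxy in place of chloro on an aromatic carbon. Its place reads word for word as that of the change from compound 1 to compound 2, so it is the same change carried onto the second core. Against that background the step that the limit leaves unreadable from compound 3 to compound 4 is expected, and this expectation rests only on the unreadable step that the two limits leave unreadable from compound 1 to compound 2 between two limits. Nothing in the set gives the change a direction. Compound 4 is therefore expected to give 80000 nM in this assay, most probably again reported only as a limit rather than a number.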

Compound 4, half-maximal inhibitory concentration: > 60000 nM
Compound 4 was reported as a limit (the forecaster's own chance of this, stated with the estimate: 85%); the middle value does not contradict the limit.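

In this assay compound 4 gives > 60000 nM as a limit and not a number. No step can be read from compound 3 to compound 4, since both ends are limits: the limit of > 60000 nM in this assay, at which 4 of the 4 values shown sit. The compounds shown leave open whether 4-chlorophenyl and 4-methoxyphenyl differ on either core, and whether the two cores differ at all in this assay.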